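From compound 3 to compound 4: methyl to benzyl

The compounds below may be only part of what the source reports. "The series", "measured", "known", "first", "only" and "open" are said of these compounds alone.

Values in a functional assay on HeLa cells (Homo sapiens) for antiproliferative activity, read by MTT assay, with a stated time of 72 h (a lower number here means a stronger inhibitor, a higher number a weaker inhibitor), so far:
- compound 1 `CCOC(=O)c1csc2nc(CN3CCN(Cc4ccccc4)CC3)c(-c3ccc(C)cc3)n12` gives 38800 nM
- compound 2 `CCOC(=O)c1csc2nc(CN3CCN(Cc4ccccc4)CC3)c(-c3ccc(OC)cc3)n12` gives 9940 nM
- compound 3 `CCOC(=O)c1csc2nc(CN3CCN(C)CC3)c(-c3ccc(Br)cc3)n12` gives 55400 nM

Compound 3 lies within the scatter of compound 1 and beyond the scatter of compound 2, which has the lower number. Compound 4 `CCOC(=O)c1csc2nc(CN3CCN(Cc4ccccc4)CC3)c(-c3ccc(Br)cc3)n12` differs from compound 3 by phenyl in place of hydrogen on a saturated chain carbon bound to an amine nitrogen in a ring, which reads as methyl to benzyl. Going by the values given here, no measured pair isolates this change. Among the compounds with values here, the only measured step, a 3.9-fold lower number from compound 1 to compound 2 (0.59 log units; beyond the scatter), is a different change between two compounds that both carry the benzyl, so it sets a scale only. A modest step to a lower number is expected, possibly none beyond the scatter. The estimate is an expected 2.2-fold lower number from compound 3 to compound 4 (0.35 log units; beyond the scatter) in this assay overall. Compound 4 is expected at 25000 nM, with an estimated range from 8000 nM to 60000 nM as its bounds.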

Compound 4, half-maximal inhibitory concentration: 29500 nM
Beside the measured number, compound 4's estimate is 1.2-fold (0.07 log units) below it, within the range that was stated.
By their numbers in this assay, from the lowest: compound 2; then compounds 4, 1 and 3 (each within the scatter of the next).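

Methyl to benzyl on a saturated chain carbon bound to an amine nitrogen in a ring gives a 1.9-fold lower number from compound 3 to compound 4 (0.27 log units; within the scatter) in this assay, so this change at this position has no effect that can be told from the scatter. With the benzyl held, the aromatic substituent does separate the compounds: a 3.0-fold higher number from compound 2 to compound 4 (0.47 log units; beyond the scatter) lies beyond the scatter, while a 1.3-fold lower number from compound 1 to compound 4 (0.12 log units; within the scatter) lies within it, so only methoxy stands apart among the three. Nothing measured explains these steps.

Open, on these data alone, is whether a longer chain ending in an amine on that nitrogen departs from methyl and benzyl. Also open, as far as these compounds go, is whether methoxy keeps its lower number with methyl on that nitrogen.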